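The compounds below may be only part of what the source reports. "The series", "measured", "known", "first", "only" and "open" are said of these compounds alone.

Measured so far in a physicochemical assay for solubility, read by spectrophotometry, in phosphate buffer, with a stated time of 2 h, at pH 7.4; a higher number here means a more soluble compound, a lower number a less soluble compound
compound 1 `COc1cccc(CN2C(=O)CN(C(=O)c3cc4cc(OC)ccc4o3)C[C@@H]2CCc2ccccc2)c1` gives 4900 nM
compound 2 `COc1ccc2[nH]c(C(=O)N3CC(=O)N(Cc4ccccc4)[C@@H](CN4CCC5(CC4)CC5)C3)cc2c1` gives 28200 nM
compound 3 `COc1cccc(CN2C(=O)CN(C(=O)c3cc4cc(OC)ccc4[nH]3)C[C@@H]2COCc2ccccc2)c1` gives 11700 nM

Of these three, compound 2 has the highest number, and compound 1 and compound 3 both lie lower by more than the usual scatter. Compound 4 `COc1ccc2[nH]c(C(=O)N3CC(=O)N(Cc4ccccc4)[C@@H](CN4CCC(OC)CC4)C3)cc2c1` keeps the core of compound 2 and changes one group, on a saturated chain carbon bound to a saturated ring carbon, where 4-methoxypiperidin-1-yl enters (a group of 8 heavy atoms (6 carbon, 1 nitrogen, 1 oxygen; one six-membered non-aromatic ring with 1 hetero atom) in place of a group of 8 heavy atoms (7 carbon, 1 nitrogen; one three-membered non-aromatic ring of carbon only, one six-membered non-aromatic ring with 1 hetero atom), on a saturated chain carbon bound to a saturated ring carbon). For the measured compounds named here, no measured pair shows this swap, so the expectation rests on compound 2 at 28200 nM and is for no step beyond the scatter. The step expected in this assay is small (a 1.2-fold higher number from compound 2 to compound 4 (0.09 log units; within the scatter)), slightly upward if anything. The estimated value for compound 4 is 35000 nM (expected range 15000 nM to 80000 nM).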

Compound 4, solubility: > 25000 nM
Compound 4 ended at the assay's limit (the forecaster's own chance of this, stated with the estimate: 10%); the middle value is on the limit's open side.
By their numbers in this assay, from the lowest: compound 1; then compound 3; then compound 2.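

In this assay compound 4 gives > 25000 nM, which is a limit of the assay and not a number. The step between compound 2 and compound 4 therefore cannot be read. The compounds shown leave open how the reading of compound 4 compares with that of compound 2.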